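A Methoxyphenyl for a Pyridinyl on Compound 2

The source may hold more compounds than are shown below. What is called first, only, known or untested is meant among the compounds shown, and "the series" means these compounds.

Compound 1 `O=C(/C=C/c1cccc(S(=O)(=O)Nc2cccc(F)c2)c1)NO`: in an assay for inhibition of histone deacetylase 8 (Homo sapiens), read by fluorescence, with a stated time of 3 h (on this read-out higher numbers stand for an effect only at larger amounts of compound and lower numbers for an effect already at smaller amounts), compound 1 gives 211 nM
Compound 2 `O=C(/C=C/c1cccc(S(=O)(=O)N2CCN(c3ccccn3)CC2)c1)NO`: in this assay compound 2 gives 581 nM

For the measured compounds named here, only two compounds carry numbers here. Compound 2 stands at the higher of the two, and compound 1 sits at a lower value; the gap between them is stated as beyond the usual scatter of this assay, so compound 2 is the weaker of the measured pair.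

Compound 3 `COc1ccc(N2CCN(S(=O)(=O)c3cccc(/C=C/C(=O)NO)c3)CC2)cc1` has not yet been measured. It differs from compound 2 in one place: 4-methoxyphenyl in place of pyridin-2-yl on an amine nitrogen in a ring. The shared core, the unsaturated hydroxamic acid on the aryl sulfonamide, is untouched.

Going by the values given here, no step between measured compounds that resembles this change exists, so there is nothing to lean on but the value of compound 2 itself. Compound 3 is therefore expected to land close to compound 2, with a step of a 1.3-fold lower number from compound 2 to compound 3 (0.11 log units; within the scatter) that may well stay within the scatter, if anything a small move toward lower numbers. The estimate for compound 3 in this assay is 450 nM, with a range from 150 nM to 1500 nM.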

Compound 3, concentration for half-maximal effect: 955 nM
Estimate against measurement, compound 3: 2.1-fold (0.33 log units) below; the range from low to high includes it.
By their numbers in this assay, from the lowest: compound 1; then compounds 2 and 3 (each within the scatter of the next).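

In this assay, putting 4-methoxyphenyl in place of pyridin-2-yl on the amine nitrogen in the ring gives a 1.6-fold higher number from compound 2 to compound 3 (0.22 log units; within the scatter), so on this one pair the exchange cannot be told from the scatter. For the compounds shown here, this is the first reading of this place, since the earlier compounds offered no pair that differed here alone: a six-membered aromatic ring of carbon only, with 8 heavy atoms in the group, stands where a ring with 1 hetero atom and 6 heavy atoms stood, and the number stays within the scatter. The ring nitrogen of pyridin-2-yl is therefore not shown to be required for the value of compound 2, although one pair cannot establish this more widely. Nothing available explains the result.

A plain phenyl group would be needed to separate the loss of the ring nitrogen from the gain of the methoxy group, and the compounds shown do not include that step. Going by these compounds, how a carboxylic acid or an amine on that aromatic ring would read in this assay also remains open.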